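The source may report more compounds than this note shows. Statements on the series, on what has been measured and on what is new or still open speak of the compounds shown alone.

Within the data shown here, in a physicochemical assay for lipophilicity, read by HPLC, measured as chromatographic lipophilicity, at pH 7.4 (a lower number here means a more polar compound, a higher number a more lipophilic compound), compound 2 `O=C(c1cccnc1)N1N=CCC1c1ccccc1` gives 2.7, the lowest of the three numbers measured so far. Compound 3 `CN1CCN(C(=O)C(C)(C)C)C(c2ccccc2)C1` stands nearest to it with 4.9, and compound 1 `C[C@@H]1C=NN(C(=O)C(C)(C)C)[C@@H]1c1ccccc1` stands furthest with 6.5. Both gaps lie well beyond the scatter of repeated measurements, so compound 2 is clearly the most polar of the three by this read-out.

The next compound, compound 4 `CC(C)(CN)C(=O)N1N=CCC1c1ccccc1`, changes compound 2 in a single place, on a carbonyl carbon whose other neighbours are an amide-type nitrogen in a ring: 1-(aminomethyl)-1-methylethyl in place of pyridin-3-yl on a carbonyl carbon. In words, 1-(aminomethyl)-1-methylethyl takes the place of pyridin-3-yl, so an aromatic ring leaves and a group with no ring enters.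

Among the measured compounds shown here, no two measured compounds differ in just one place, so no measured step can serve as a guide to the size of this change. The expectation therefore starts from compound 2 at 2.7 and remains uncertain. The expected step is a number 0.20 log units lower from compound 2 to compound 4 (within the scatter), a small move downward that would not stand out from the scatter. For compound 4 the estimate in this assay is 2.5, with an expected range from 1.5 to 3.6.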

Compound 4, distribution coefficient: 1.4
Beside the measured number, compound 4's estimate is 1.10 log units above it; the whole stated range lies above it.
By their numbers in this assay, from the lowest: compound 4; then compound 2; then compound 3; then compound 1.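

Among these compounds, this is the first measured step between two compounds that differ in one place, and it shows that the group on this carbonyl carbon, whose other neighbour is an amide-type nitrogen in a ring, can move the read-out substantially. In this assay, putting 1-(aminomethyl)-1-methylethyl in place of pyridin-3-yl gives a number 1.30 log units lower from compound 2 to compound 4 (beyond the scatter). The swap changes several things at once: an aromatic ring leaves, a group with no ring enters, and the entering group has 1 hydrogen-bond donor where the leaving group has 0, while no measurement shown here ties the step to any one of these differences.

Still open, going by these compounds, is how much of the step follows the loss of the aromatic ring and how much follows the amine, which a pyridin-4-yl or a cyclohexyl group at this carbonyl carbon could begin to separate. Also open, on these data alone, is whether a hydroxyl or a carboxylic acid in place of the amine, on the same chain, would give a step of similar size.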